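The compounds below may be only part of what the source reports. "The series", "measured", "known", "first", "only" and "open" are said of these compounds alone.

Two related compounds share one core: compound 1 `Cc1ccc(CN2CCCC(COc3ccc(-c4nc5cc(C(N)=O)ccc5[nH]4)cc3)C2)cc1` and compound 2 `Cc1ccc(CN2CCCCC2CCOc2ccc(-c3nc4cc(C(N)=O)ccc4[nH]3)cc2)cc1`. In a physicochemical assay for solubility, with a stated time of 3 days, at pH 2 (a lower number here means a less soluble compound, a higher number a more soluble compound), compound 1 stands as "not determined" (no result reported), so it offers no guidance. Compound 2 gives > 400000 nM, which is a limit of the assay and not a single number. This limit is the only reference point available.

Compound 3 `CC(=O)N1CCCCC1CCOc1ccc(-c2nc3cc(C(N)=O)ccc3[nH]2)cc1` keeps the shared core and changes one group, with acetyl in place of 4-methylbenzyl on an amine nitrogen in a ring. Among the measured compounds shown here, no pair of measured compounds shows what such a swap does in this assay, so any forecast rests on that one limit. The expected change is small: none beyond the usual scatter, or a modest fall in the read-out. The estimated move is an at least 1.3-fold lower number from compound 2 to compound 3 (0.12 log units; that floor lies within the scatter). Compound 3 is expected at 300000 nM, with an estimated range from 80000 nM to 400000 nM.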

Compound 3, solubility: > 400000 nM
Compound 3: no number, only a limit; the forecaster's own chance of this, stated with the estimate: 55%; middle value at least 1.3-fold (0.12 log units) from the limit.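

Among the compounds shown here, no step from compound 2 to compound 3 can be read in this assay, because both compounds give only a limit and not a single number: the limit of > 400000 nM in this assay, at which 2 of the 3 values shown sit.

On these data alone, whether acetyl in place of 4-methylbenzyl changes the read-out at all remains open.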